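Fluoro in Place of Chloro in a Growth Inhibition Test

The compounds below may be only part of what the source reports. "The series", "measured", "known", "first", "only" and "open" are said of these compounds alone.

Measured so far:
compound 1 (`O=S(=O)(/C=C/c1ccc(F)cc1Cl)Cc1ccc(Nc2ncnc3ccccc23)cc1`) gives 100000 nM
compound 2 (`O=S(=O)(/C=C/c1ccc(Cl)cc1Cl)Cc1ccc(Nc2ncnc3cc(Cl)ccc23)cc1`) gives 32000 nM

In a functional assay on UACC-62 cells (Homo sapiens) (a lower number here means a stronger inhibitor of growth, a higher number a weaker inhibitor of growth), compound 2 has the lower of the two numbers at 32000 nM while compound 1 gives 100000 nM and that gap lies beyond the usual scatter. These two compounds differ in more than one place, so their gap cannot be pinned on any single change.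

Compound 3 (`O=S(=O)(/C=C/c1ccc(F)cc1Cl)Cc1ccc(Nc2ncnc3cc(Cl)ccc23)cc1`) changes compound 2 in one place, with fluoro in place of chloro on an aromatic carbon, turning the 2,4-dichlorophenyl into 2-chloro-4-fluorophenyl. Going by the values given here, no measured pair shows this change alone, so the expectation is loose: a small step toward a higher number, perhaps within the scatter. Compound 1, which also carries 2-chloro-4-fluorophenyl, gives 100000 nM and this leans the same way. The expected change is a 1.4-fold higher number from compound 2 to compound 3 (0.15 log units; within the scatter) in this assay and it remains an estimate. Compound 3 is estimated at 45000 nM (expected range 18000 nM to 100000 nM).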

Compound 3, concentration for 50% growth inhibition: 72000 nM
Beside the measured number, compound 3's estimate is 1.6-fold (0.20 log units) below it; measured number inside the range.
By their numbers in this assay, from the lowest: compound 2; then compounds 3 and 1 (each within the scatter of the next).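

In this assay, the change from 2,4-dichlorophenyl to 2-chloro-4-fluorophenyl now has its first direct reading, a 2.3-fold higher number from compound 2 to compound 3 (0.35 log units; beyond the scatter), so chloro at this position gives a modest but real advantage over fluoro. The same set also isolates the chloro on the shared core, where compound 3 carries chloro and compound 1 carries hydrogen: a 1.4-fold lower number from compound 1 to compound 3 (0.14 log units; within the scatter), which stays within the scatter. Of the two single changes that separate compound 1 from compound 2, only the swap of fluoro for chloro on the phenyl ring is therefore a step beyond the scatter when read alone.

No measurement here accounts for this step. Still open, from the compounds shown here alone, is how a methoxy or a nitrile at this position would compare with chloro and fluoro, and whether the fluoro step holds on a core with no chloro.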